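This account rests on a few compounds, and the source may have more. Where it says the series, first, only, none or still open, it means among the compounds named here.

Compound 1, `O=c1c(C(=S)Nc2ccccc2)coc2ccccc12`: in a functional assay on OVCAR-3 cells (Homo sapiens) for inhibition, read by sulforhodamine B assay, with a stated time of 48 h (on this read-out higher numbers stand for weaker inhibition and lower numbers for stronger inhibition), compound 1 gives 86400 nM.
Compound 2, `O=c1c(C2N=C(c3ccccc3)SS2)coc2ccccc12`: compound 2 gives > 100000 nM, which is a limit of the assay and not a number.
Compound 3, `O=c1c(C2N=C(c3ccccc3)SS2)coc2cc(Cl)ccc12`: compound 3 gives 10500 nM.

Compound 2 thus stands at the weak end of these numbers, known only as a limit. Compound 4, `Cc1ccc2occ(C3N=C(c4ccccc4)SS3)c(=O)c2c1`, differs from compound 2 by methyl in place of hydrogen on an aromatic carbon. One measured step resembles it, also a change on an aromatic carbon: an at least 9.5-fold lower number from compound 2 to compound 3 (0.97 log units; beyond the scatter). Because compound 2 sits at the limit of > 100000 nM in this assay, at which 1 of the 3 values shown sits, the true size of that step is open. For the measured compounds named here, a methyl is a different group from a chloro, and no measured pair tests it here. A lowering of the number is expected for compound 4, an at least 2.5-fold lower number from compound 2 to compound 4 (0.39 log units; beyond the scatter), smaller than the chloro step. Compound 4 is therefore estimated at 40000 nM, with a range from 10000 nM to 150000 nM.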

Compound 4, half-maximal inhibitory concentration: 93700 nM
The estimate for compound 4 lay 2.3-fold (0.37 log units) below the measured number, and the stated range covers the measured number.
By their numbers in this assay, from the lowest: compound 3; then compounds 1 and 4 (each within the scatter of the next). At a limit, above all of these: compound 2.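

In this assay, methyl in place of hydrogen on this aromatic carbon gives an at least 1.0-fold lower number from compound 2 to compound 4 (0.02 log units; that floor lies within the scatter), so this change brings no clear lowering of the number. That floor does not fix the true size of the step, because compound 2 is known only as a limit: the limit of > 100000 nM in this assay, at which 1 of the 4 values shown sits.

The compounds shown leave open whether a chloro on this same carbon would lower the number as it does in compound 3. They also leave open what an amine, a methoxy group or a carboxylic acid would do there.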